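The compounds below may be only part of what the source reports. "The series", "measured", "known", "first", "only" and "open" are said of these compounds alone.

Going by the values given here, compound 1 `CCN(Cc1ccncc1)C(=S)SCc1ccc(C(=O)Nc2ccccc2N)cc1` gives 85.2% in a functional assay on MGC-803 cells (Homo sapiens) for antiproliferative activity, read by CCK-8 assay, with a stated time of 72 h, tested at 8 uM (a lower number here means a weaker effect, a higher number a stronger effect of the compound at the concentration tested), the higher of the two numbers so far, while compound 2 `Nc1ccccc1NC(=O)c1ccc(CSC(=S)N2CCN(Cc3ccncc3)CC2)cc1` gives 79.3%, a gap within the scatter, so the two are not ranked against each other. Compound 3 `Nc1ccccc1NC(=O)c1ccc(CSC(=S)N2CCCC2)cc1` is the untested member; against compound 1 the change is pyrrolidin-1-yl in place of ethyl((pyridin-4-yl)methyl)amino on a thiocarbonyl carbon. Among the compounds with values here, no step between tested compounds isolates this change, so the expectation rests on the two values alone. A moderate downward step, a number 15.2 percentage points lower from compound 1 to compound 3 (beyond the scatter), is expected in this assay, probably just beyond the scatter. Compound 3 is estimated at 70%, within 45% to 88%.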

Compound 3, a percentage reported as inhibition, at one concentration (the size of the read-out at that concentration, not a potency): 83.4%
The estimate for compound 3 lay 13.4 percentage points below the measured number; measured number inside the range.
By their numbers in this assay, from the lowest: compounds 2, 3 and 1 (each within the scatter of the next).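

On the thiocarbonyl carbon, pyrrolidin-1-yl in place of ethyl((pyridin-4-yl)methyl)amino gives a number 1.8 percentage points lower from compound 1 to compound 3 (within the scatter) in this assay. This position therefore tolerates the loss of the six-membered aromatic ring and of the hydrogen-bond acceptor counted in the leaving group, with no change beyond the scatter in this read-out. No available measurement accounts for this result.

From the compounds shown here alone, whether morpholin-4-yl or a small open-chain dimethylamino group at this carbon would hold the inhibition remains open. Readings at a single concentration also leave open whether compound 1, compound 2 and compound 3 would differ in the strength of their effect at other concentrations.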